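Moving a Chlorine on the Dichlorophenyl Ring

A few compounds are considered here, and "the series" means these few. Any claim that something is new, unique, unknown or untested is made for them only; others in the source may bear on it.

Compound 1 `COc1cccc(/C=C2\CCC/C(=C\c3ccc(Cl)cc3)C2=O)c1OC` gives 18600 nM
Compound 2 `COc1cccc(/C=C2\CCC/C(=C\c3ccc(Cl)cc3Cl)C2=O)c1OC` gives 49200 nM

In an ADME assay on NHDF cells (Homo sapiens) for cytotoxicity, read by MTT assay, with a stated time of 72 h (on this read-out lower numbers stand for stronger inhibition and higher numbers for weaker inhibition), compound 2 gives 49200 nM as the higher of the two numbers, so it stands at the weak end of this small set. Compound 3 `COc1cccc(/C=C2\CCC/C(=C\c3ccc(Cl)c(Cl)c3)C2=O)c1OC` is still unmeasured, and its difference from compound 2 is 3,4-dichlorophenyl in place of 2,4-dichlorophenyl on a double-bonded chain carbon bound to a double-bonded ring carbon with nothing else changed. For the measured compounds named here, the one measured step that bears on this is a 2.6-fold higher number from compound 1 to compound 2 (0.42 log units; beyond the scatter) and it is modest. That step ended in the 2,4-dichlorophenyl of compound 2, which compound 3 gives up for a 3,4-dichlorophenyl not yet tested in this assay by any compound. Going by the values given here, with compound 1 at 18600 nM as the only lower number, a small move towards it is expected, one that may not clear the usual scatter. The expected change is a 1.8-fold lower number from compound 2 to compound 3 (0.24 log units; within the scatter) and it rests on that single step. Compound 3 is estimated at 28000 nM within an expected range from 11000 nM to 70000 nM for now.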

Compound 3, half-maximal inhibitory concentration: 25500 nM
Compound 3: middle estimate off by 1.1-fold (0.04 log units), on the high side; the measured number falls inside the stated range.
By their numbers in this assay, from the lowest: compounds 1, 3 and 2 (each within the scatter of the next, the first and the last beyond it).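

Compound 2 and compound 3 hold the same atoms, so swapping 2,4-dichlorophenyl for 3,4-dichlorophenyl tests only how the two chlorines are arranged. In this assay that swap gives a 1.9-fold lower number from compound 2 to compound 3 (0.29 log units; within the scatter) and so this read-out cannot tell the two arrangements apart. The added chlorine can now be read in two forms: the 3,4-dichlorophenyl gives a 1.4-fold higher number from compound 1 to compound 3 (0.14 log units; within the scatter) and the 2,4-dichlorophenyl gave a 2.6-fold higher number from compound 1 to compound 2 (0.42 log units; beyond the scatter) so only the second addition clears the scatter, even though compound 2 and compound 3 themselves cannot be separated.

Nothing in the available data accounts for these numbers. As far as these compounds go, it remains open whether an amine or a carboxylic acid in place of the second chlorine on this ring would move the number clearly away from those of compound 1 and compound 2.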